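The source may report more compounds than this note shows. Statements on the series, on what has been measured and on what is new or still open speak of the compounds shown alone.

In an ADME assay on cells (Hepatocyte, Homo sapiens) for metabolic stability, with a stated time of 30 min (on this read-out lower numbers stand for a less stable compound and higher numbers for a more stable compound), compound 1 (`CS(=O)(=O)NC1CCC(CN2CCN(c3cc(=O)c4cc(C(F)(F)F)cc([N+](=O)[O-])c4s3)CC2)CC1`) gives 105%, compound 2 (`O=c1cc(N2CCN(CC3CCC(NS(=O)(=O)c4ccccc4)CC3)CC2)sc2c([N+](=O)[O-])cc(C(F)(F)F)cc12`) gives 90.8% and compound 3 (`O=C(NC1CCC(CN2CCN(c3cc(=O)c4cc(C(F)(F)F)cc([N+](=O)[O-])c4s3)CC2)CC1)c1ccccc1`) gives 92.9%. Compound 3 therefore stands level with compound 2 within the scatter, a number 2.1 percentage points higher from compound 2 to compound 3 (within the scatter), and clearly short of compound 1, a number 12.1 percentage points lower from compound 1 to compound 3 (beyond the scatter).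

Compound 4 (`O=C(OC1CCC(CN2CCN(c3cc(=O)c4cc(C(F)(F)F)cc([N+](=O)[O-])c4s3)CC2)CC1)c1ccncc1`) carries ((pyridin-4-yl)carbonyl)oxy in place of benzamido on a saturated ring carbon. Going by the values given here, no measured step makes this exchange, so the closest evidence comes from the changes on the amine nitrogen. Replacing methyl with phenyl on the sulfonyl sulfur gave a number 14.2 percentage points lower from compound 1 to compound 2 (beyond the scatter), which, like the benzoyl step from compound 1, was modest and downward. Among the compounds with values here, the data include no compound that lacks this amine nitrogen, so the range stays wide. A modest fall in this assay is expected, a number 12.9 percentage points lower from compound 3 to compound 4 (beyond the scatter). The estimated value for compound 4 is 80%, with an expected range of 58% to 98%.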

Compound 4, percent of the compound remaining: 1%
Compound 4: middle estimate off by 79 percentage points, on the high side; measured number outside the range, below it.
By their numbers in this assay, from the lowest: compound 4; then compounds 2 and 3 (each within the scatter of the next); then compound 1.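

Up to this point, exchanges among the nitrogen-linked groups on the saturated ring carbon had shifted this assay modestly at most, so the position looked tolerant of change. Putting ((pyridin-4-yl)carbonyl)oxy there ends that picture, with a number 91.9 percentage points lower from compound 3 to compound 4 (beyond the scatter), and the loss is just as large against the two sulfonyl-bearing groups, with a number 89.8 percentage points lower from compound 2 to compound 4 (beyond the scatter) and a number 104 percentage points lower from compound 1 to compound 4 (beyond the scatter). No measurement available here accounts for this collapse.

The exchange alters two things at once, the nitrogen link giving way to an oxygen link and the carbon-only aromatic ring giving way to one with a hetero atom, so the compounds shown cannot assign the loss to either. A benzoyloxy group, or a pyridine-4-carboxamido group, at the same carbon would separate the two changes.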